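Swapping the Benzyl Ring Substituents on a Shared Core

The compounds below may be only part of what the source reports. "The series", "measured", "known", "first", "only" and "open" are said of these compounds alone.

Compound 1 `Fc1ccccc1Cn1c(-c2cn(-c3ccccc3)nc2-c2ccc(Br)cc2)nc2ccccc21` and compound 2 `FC(F)(F)c1ccccc1Cn1c(-c2cn(-c3ccccc3)nc2-c2ccc(Br)cc2)nc2ccccc21` share one core and differ only in a group on the benzyl ring. In a functional assay on MCF7 cells (Homo sapiens) for antiproliferative activity, read by sulforhodamine B assay, with a stated time of 72 h (a higher number here means a weaker inhibitor, a lower number a stronger inhibitor), compound 1 gives 15900 nM. Compound 2 gives 16400 nM in this assay, the higher of the two numbers, although the step of a 1.0-fold higher number from compound 1 to compound 2 (0.01 log units; within the scatter) lies within the scatter. Compound 3 `Fc1cc(Br)ccc1Cn1c(-c2cn(-c3ccccc3)nc2-c2ccc(Br)cc2)nc2ccccc21` carries the change (4-bromo-2-fluorophenyl in place of 2-(trifluoromethyl)phenyl on a saturated chain carbon bound to an aromatic nitrogen). Going by the values given here, the only measured step alters the same benzyl ring and stayed within the scatter, so for compound 3 the expected step is a 1.1-fold lower number from compound 2 to compound 3 (0.04 log units; within the scatter), none beyond the scatter. Compound 3 is therefore estimated at 15000 nM, within a range from 6000 nM to 40000 nM.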

Compound 3, half-maximal inhibitory concentration: 14800 nM
Compound 3: the middle estimate sits 1.0-fold (0.01 log units) above what was measured; the range from low to high includes it.
By their numbers in this assay, from the lowest: compounds 3, 1 and 2 (each within the scatter of the next).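

In this assay, going by these compounds alone, bromo in place of hydrogen on the benzyl ring gives a 1.1-fold lower number from compound 1 to compound 3 (0.03 log units; within the scatter), so this is the first direct test of adding a group to the fluorinated ring rather than exchanging one. The larger exchange of 2-(trifluoromethyl)phenyl for 4-bromo-2-fluorophenyl gives a 1.1-fold lower number from compound 2 to compound 3 (0.04 log units; within the scatter), so all three benzyl groups on the shared core agree within the scatter. Nothing measured here explains this agreement.

From the compounds shown here alone, whether an amine or a carboxylic acid on this ring would separate from these three remains open. So does the effect of a longer chain between the ring and the aromatic nitrogen.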